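From a Dimethylamide to a Pyrrolidinyl Amide

A few compounds are considered here, and "the series" means these few. Any claim that something is new, unique, unknown or untested is made for them only; others in the source may bear on it.

Of the compounds shown here, two sharing one core have been tested so far in an assay on lysate for inhibition of 6-phosphofructo-2-kinase/fructose-2,6-bisphosphatase 3 (Homo sapiens), with stated times of 0.5 min and 45 min; on this read-out higher numbers stand for weaker inhibition and lower numbers for stronger inhibition. Compound 1 `CN1CCC(NS(=O)(=O)c2ccccc2Nc2cc(-c3ccc4ccn(C)c4c3)c3nccnc3c2)C1` gives 3160 nM. Compound 2 `CN(C)C(=O)c1ccncc1Nc1cc(-c2ccc3ccn(C)c3c2)c2nccnc2c1` gives only the limit of the assay, > 100000 nM, so no number is known for it. One of the two values therefore stands at the limit of > 100000 nM in this assay, at which 1 of the 2 values shown sits, and that is where compound 2 sits. Compound 3 `CC(=O)N1CCC(NC(=O)c2ccncc2Nc2cc(-c3ccc4ccn(C)c4c3)c3nccnc3c2)C1` has not been measured yet. It differs from compound 2 in one place: (1-acetylpyrrolidin-3-yl)amino in place of dimethylamino on a carbonyl carbon. Within the data shown here, because compound 2 is known only as a limit in this assay, no measured step is available, and the two values alone say nothing about what this change should do. Compound 3 keeps the carbonyl of compound 2 while taking on a ring-bearing amine, and compound 1, with its value of 3160 nM, shows that a ring-bearing amine on this core can go with measurable inhibition. The estimate for compound 3 is 30000 nM, with a range from 5000 nM to 150000 nM, and the expected step of an at least 3.3-fold lower number from compound 2 to compound 3 (0.52 log units; beyond the scatter) is toward stronger inhibition though uncertain in size.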

Compound 3, half-maximal inhibitory concentration: > 100000 nM
Compound 3 ended at the assay's limit; the forecaster's own chance of this, stated with the estimate: 40%; at least 3.3-fold (0.52 log units) between middle value and limit.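

Compound 3 gives > 100000 nM, which is a limit of the assay and not a number. Compound 2 stands at a limit as well, so no step between compound 2 and compound 3 can be read: the limit of > 100000 nM in this assay, at which 2 of the 3 values shown sit.

The compounds shown leave open whether (1-acetylpyrrolidin-3-yl)amino in place of dimethylamino on a carbonyl carbon changes inhibition at all.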